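Lengthening the amide chain: isopropyl to hexyl

The source may hold more compounds than are shown below. What is called first, only, known or untested is meant among the compounds shown, and "the series" means these compounds.

Compound 1 `CCCCNC(=O)/C=C/c1c(/C=C/c2ccc(OC)cc2)cc(OC)cc1OC` gives 2080 nM in a functional assay on B16-F10 cells (Mus musculus) for inhibition, read by MTT assay, with a stated time of 48 h; on this read-out lower numbers stand for stronger inhibition and higher numbers for weaker inhibition.
Compound 2 `COc1ccc(/C=C/c2cc(OC)cc(OC)c2/C=C/C(=O)NC(C)C)cc1` gives 4020 nM in this assay.

Compound 2 carries the higher of the two numbers shown, but its only neighbour, compound 1, lies within the usual scatter of it, so the two cannot be ranked. Compound 3 `CCCCCCNC(=O)/C=C/c1c(/C=C/c2ccc(OC)cc2)cc(OC)cc1OC` differs from compound 2 in one place: hexyl in place of isopropyl on an amide-type nitrogen. Within the data shown here, the single measured step that bears on this change is a 1.9-fold higher number from compound 1 to compound 2 (0.29 log units; within the scatter), a shortening of the chain on the same nitrogen that moved the number by less than the scatter. Going the other way, to a chain longer than the butyl of compound 1, is expected to move the number little, if at all, and most plausibly downward. On that basis this step is estimated at a 2.0-fold lower number from compound 2 to compound 3 (0.30 log units; within the scatter) in this assay. Compound 3 is expected to give about 2000 nM, with a range from 800 nM to 5000 nM.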

Compound 3, half-maximal inhibitory concentration: 7180 nM
Compound 3: middle estimate off by 3.6-fold (0.56 log units), on the low side; measured number outside the range, above it.
By their numbers in this assay, from the lowest: compounds 1, 2 and 3 (each within the scatter of the next, the first and the last beyond it).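

In this assay compound 3 cannot be told apart from compound 2 (a 1.8-fold higher number from compound 2 to compound 3 (0.25 log units; within the scatter)), so hexyl and isopropyl on this amide nitrogen give numbers within the usual scatter of each other. Among these compounds, the comparison with butyl does separate (a 3.5-fold higher number from compound 1 to compound 3 (0.54 log units; beyond the scatter)): this modest step is the first at this position to clear the scatter, and it shows that hexyl gives weaker inhibition than butyl here. Nothing measured here accounts for this difference.

The compounds shown leave open whether the butyl chain marks a real optimum, which would take neighbouring chains such as propyl and pentyl to judge. They also leave open how a ring such as cyclohexyl, or an amine or carboxylic acid at the end of the chain, would fare on this nitrogen.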